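The compounds below may be only part of what the source reports. "The series", "measured", "known", "first", "only" and "open" are said of these compounds alone.

Working notes on the series. Compound 1 `COc1ccc(C(=O)c2ccc(F)cc2)cc1OCC(=O)OC[C@@H]1C=C[C@H](n2cc(C)c(=O)[nH]c2=O)O1` gives 40300 nM in a functional assay on SMMC-7721 cells (Homo sapiens) for antiproliferative activity, read by MTT assay, with a stated time of 48 h; a higher number here means a weaker inhibitor, a lower number a stronger inhibitor. Compound 2 `COc1ccc(C(=O)c2ccc([N+](=O)[O-])cc2)cc1OC(=O)CCC(=O)OC[C@@H]1C=C[C@H](n2cc(C)c(=O)[nH]c2=O)O1` gives 30500 nM in this assay. Compound 3 `COc1ccc(C(=O)c2ccccc2OC)cc1OCC(=O)OC[C@@H]1C=C[C@H](n2cc(C)c(=O)[nH]c2=O)O1` gives 32300 nM in this assay and sits second highest of the three numbers, nearest compound 2 and furthest from compound 1; both gaps lie within the scatter, so the three measured compounds cannot be told apart on these numbers. Within the data shown here, the only single-point step among them is a 1.2-fold lower number from compound 1 to compound 3 (0.10 log units; within the scatter), which also lies within the scatter.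

Compound 4 `COc1ccc(C(=O)c2ccccc2Cl)cc1OCC(=O)OC[C@@H]1C=C[C@H](n2cc(C)c(=O)[nH]c2=O)O1` differs from compound 3 in one place: chloro in place of methoxy on an aromatic carbon. Among the measured compounds shown here, the one measured step that touches the same ring, a 1.2-fold lower number from compound 1 to compound 3 (0.10 log units; within the scatter), moved nothing beyond the scatter, and no measured pair exchanges methoxy for chloro. For the measured compounds named here, with no step of this kind on record and the only related step flat, the change is expected to give a 1.1-fold lower number from compound 3 to compound 4 (0.03 log units; within the scatter) in this assay, with no direction that can be justified from the measured compounds. Compound 4 is therefore estimated at 30000 nM in this assay, with a range from 12000 nM to 75000 nM that reflects the scatter and the absence of a direct precedent.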

Compound 4, half-maximal inhibitory concentration: 40600 nM
Compound 4: the middle estimate sits 1.4-fold (0.13 log units) below what was measured, within the range that was stated.
By their numbers in this assay, from the lowest: compounds 2, 3, 1 and 4 (each within the scatter of the next).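

Among these compounds, on the aromatic carbon ortho to a large group, chloro in place of methoxy gives a 1.3-fold higher number from compound 3 to compound 4 (0.10 log units; within the scatter) in this assay, so the one measured exchange of these two groups at this place lies within the scatter. The step from a different aryl group, 2-chlorophenyl in place of 4-fluorophenyl on a carbonyl carbon, gives a 1.0-fold higher number from compound 1 to compound 4 (0.00 log units; within the scatter) and also lies within the scatter, which leaves compound 1, compound 3 and compound 4 indistinguishable in this assay across the three aryl groups they carry. No evidence is available to explain these results.

The compounds shown cover only methoxy and chloro at this place, together with the 4-fluorophenyl group of compound 1, so they leave open whether an amine, a hydroxyl or a carboxylic acid on this aromatic ring would give a step beyond the scatter in this assay. Among the compounds shown here, also open is what the chain joining the shared core to the aryl ketone part contributes, since compound 2 differs from the others in more than one place and no single-point step covers a longer chain.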